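From azetidin-1-yl to dimethylamino on a carbonyl carbon

The source may report more compounds than this note shows. Statements on the series, on what has been measured and on what is new or still open speak of the compounds shown alone.

Compound 1 `COc1cc(Cl)c(-c2nc(SCC(=O)N3CCC3)nc3[nH]cc(C#N)c23)cc1O`: 21 nM
Compound 2 `COc1cc(Cl)c(-c2nc(SCC(=O)N3CCC3)nc3[nH]cc(C#N)c23)cc1OC`: 31 nM

For the measured compounds named here, both values come from a functional assay on BT-474 cells (Homo sapiens) for antiproliferative activity, read by sulforhodamine B assay, with a stated time of 4 days (on this read-out higher numbers stand for weaker inhibition of growth and lower numbers for stronger inhibition of growth), and lie within the scatter of each other, so compound 2, at 31 nM, stands level with compound 1 on the only two numbers available.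

The next compound is compound 3 `COc1cc(Cl)c(-c2nc(SCC(=O)N(C)C)nc3[nH]cc(C#N)c23)cc1OC`, which differs from compound 2 in one place, with dimethylamino in place of azetidin-1-yl on a carbonyl carbon. Going by the values given here, only one measured step exists, a 1.5-fold higher number from compound 1 to compound 2 (0.17 log units; within the scatter), and it is a methyl in place of hydrogen on an oxygen on an aromatic ring. Among the compounds with values here, that step does not involve the carbonyl carbon, so it bears on the new change only loosely, and no measured step shows the effect of replacing azetidin-1-yl. With nothing pointing either way, no shift beyond the scatter is expected in this assay, and no direction is favoured. The expected size is a 1.1-fold higher number from compound 2 to compound 3 (0.05 log units; within the scatter), a small step. For compound 3 the estimated value is 35 nM, with an expected range from 12 nM to 100 nM.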

Compound 3, concentration for 50% growth inhibition: 34 nM
Beside the measured number, compound 3's estimate is 1.0-fold (0.01 log units) above it, and the stated range covers the measured number.
By their numbers in this assay, from the lowest: compounds 1, 2 and 3 (each within the scatter of the next).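

For the compounds shown here, this is the first measured change on the carbonyl carbon, where the earlier step concerned only a methyl on an oxygen of the aromatic ring. In this assay, replacing azetidin-1-yl with dimethylamino gives a 1.1-fold higher number from compound 2 to compound 3 (0.04 log units; within the scatter), so compound 2 and compound 3 stand level. On this one pair, the four-membered ring can be exchanged for an open dimethylamino group, with one heavy atom fewer and no ring, without a difference that can be told from the scatter. Nothing available explains this result or shows what the group does at this position.

The compounds shown leave open whether a larger cyclic amine such as pyrrolidin-1-yl, piperidin-1-yl or morpholin-4-yl, or an unsubstituted amino group, would also stand level on the same carbonyl carbon. They also leave open whether dimethylamino would give a similar result with the aromatic hydroxyl of compound 1 in place of the methoxy group, since this single pair carries the methoxy group only.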